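Notes on the aminoquinazolinone glutamate series

This account rests on a few compounds, and the source may have more. Where it says the series, first, only, none or still open, it means among the compounds named here.

Measured so far:
compound 1 `Nc1nc(O)c2cc(CN(CC3CC3)c3ccc(C(=O)NC(CCC(=O)O)C(=O)O)cc3)ccc2n1` — 8000 nM
compound 2 `Nc1nc(O)c2cc(CN(CCC(=O)O)c3ccc(C(=O)NC(CCC(=O)O)C(=O)O)cc3)ccc2n1` — 32000 nM

Both compounds were tested in an assay on lymphoma cells for inhibition of Trifunctional purine biosynthetic protein adenosine-3 (Mus musculus); on this read-out higher numbers stand for weaker inhibition and lower numbers for stronger inhibition. Compound 2 stands at the highest of the two numbers; its nearest neighbour is compound 1, and the step of a 4.0-fold higher number from compound 1 to compound 2 (0.60 log units; beyond the scatter) separates them.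

Compound 3 `Nc1nc(O)c2cc(CN(Cc3cnc(O)nc3O)c3ccc(C(=O)NC(CCC(=O)O)C(=O)O)cc3)ccc2n1` is not yet measured. It differs from compound 2 in one place: 2,4-dihydroxypyrimidin-5-yl in place of carboxymethyl on a saturated chain carbon bound to a nitrogen on an aromatic ring.

For the measured compounds named here, only one measured step touches this position, the step from compound 1 to compound 2, which was modest and beyond the scatter. Going by the values given here, no measured pair shows an aromatic ring at this position, so the direction of the change is open. The expectation is a modest shift in this assay, most likely back toward the number of compound 1, with wide uncertainty.

For compound 3 the estimated value is 15000 nM, with a range from 4000 nM to 60000 nM; this estimate corresponds to the step of a 2.1-fold lower number from compound 2 to compound 3 (0.33 log units; beyond the scatter).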

Compound 3, inhibition constant: 7000 nM
Compound 3: middle estimate off by 2.1-fold (0.33 log units), on the high side, within the range that was stated.
By their numbers in this assay, from the lowest: compounds 3 and 1 (each within the scatter of the next); then compound 2.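

In this assay the change to 2,4-dihydroxypyrimidin-5-yl on the saturated chain carbon bound to a nitrogen on an aromatic ring gives a 4.6-fold lower number from compound 2 to compound 3 (0.66 log units; beyond the scatter) and shows that this place holds an aromatic ring with two hetero atoms without the loss seen with carboxymethyl. Set against cyclopropyl, the same group gives a 1.1-fold lower number from compound 1 to compound 3 (0.06 log units; within the scatter) so these two groups cannot be told apart here, though they differ in ring size and in what is counted on them, and carboxymethyl alone stands apart among the three. No measurement at hand accounts for these differences.

Open, going by these compounds, is whether the ring or its two hydroxyl groups set the number, which a plain phenyl or an unsubstituted pyrimidin-5-yl at this place would separate. Also open, on these data alone, is how an amine or a longer chain ending in a carboxylic acid would read here.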